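Swapping an Alkyne Arm for Iodine on a Shared Core

The source may hold more compounds than are shown below. What is called first, only, known or untested is meant among the compounds shown, and "the series" means these compounds.

Measured so far:
compound 1, `O=C(O)c1ccc(C#Cc2ccc3c(c2)C=C([N+](=O)[O-])C(C(F)(F)F)O3)cc1`: 2100 nM
compound 2, `CC(=O)NCC#Cc1ccc2c(c1)C=C([N+](=O)[O-])C(C(F)(F)F)O2`: 1100 nM

In an assay on isolated protein for inhibition of D(1B) dopamine receptor (Homo sapiens) (on this read-out lower numbers stand for stronger inhibition and higher numbers for weaker inhibition), compound 2 gives 1100 nM and compound 1 gives 2100 nM. Among the measured compounds shown here, the only measured step, a 1.9-fold lower number from compound 1 to compound 2 (0.28 log units; within the scatter), swapped acetamidomethyl for 4-carboxyphenyl on a triple-bonded carbon, and its size leaves the two compounds indistinguishable within the scatter.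

Compound 3, `O=[N+]([O-])C1=Cc2cc(I)ccc2OC1C(F)(F)F`, has not yet been measured. It differs from compound 2 by iodo in place of 3-acetamidoprop-1-yn-1-yl on an aromatic carbon. The measured step touched the same attachment point but kept the alkyne arm; here the whole arm is removed and a single iodine enters. That one step therefore bears only loosely on this change, and it suggests that the group at this position has so far moved this assay little. No step beyond the scatter is expected from compound 2 to compound 3, a 1.4-fold higher number from compound 2 to compound 3 (0.13 log units; within the scatter). Compound 3 is estimated at 1500 nM, with a range from 400 nM to 6000 nM.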

Compound 3, inhibition constant: 1600 nM
For compound 3 the middle estimate is 1.1-fold (0.03 log units) below the measured one; low and high end bracket the measured number.
By their numbers in this assay, from the lowest: compounds 2, 3 and 1 (each within the scatter of the next).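

Replacing the whole 3-acetamidoprop-1-yn-1-yl arm with a single iodine in this assay gives a 1.5-fold higher number from compound 2 to compound 3 (0.16 log units; within the scatter), even though this change is far larger than the swap at the far end of the alkyne arm. Compound 3 has no triple bond, no amide and no hydrogen-bond donor or acceptor in this group, so none of these features of the arm is needed for a number in this range on the shared core. No measurement here explains why such different groups give numbers within the scatter of each other.

From the compounds shown here alone, whether any group on this aromatic carbon can move the number beyond the scatter remains open. A plain hydrogen or an amine placed directly on this carbon would test whether the iodine itself contributes anything, or whether the core alone sets the number.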